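This account rests on a few compounds, and the source may have more. Where it says the series, first, only, none or still open, it means among the compounds named here.

Of the compounds shown here, three built on one shared core have been tested so far, and they differ only in the group on one aromatic carbon. In a functional assay on OCI-AML2 cells (Homo sapiens) for antiproliferative activity, read by WST assay, with a stated time of 3 days (on this read-out higher numbers stand for weaker inhibition and lower numbers for stronger inhibition), compound 1 (`[N-]=[N+]=Nc1cc(=O)[nH]c(=O)n1[C@@H]1O[C@H](CO)[C@@H](O)[C@H]1O`), which carries azido, gives > 50000 nM, a limit of the assay and not a number. Compound 2 (`CNc1cc(=O)[nH]c(=O)n1[C@@H]1O[C@H](CO)[C@@H](O)[C@H]1O`), which carries methylamino, gives > 50000 nM, again a limit. Compound 3 (`O=c1cc(NO)n([C@@H]2O[C@H](CO)[C@@H](O)[C@H]2O)c(=O)[nH]1`), which carries hydroxyamino, gives > 50000 nM, also a limit. Compound 3 therefore has no exact number and stands with the other two: the limit of > 50000 nM in this assay, at which 3 of the 3 values shown sit.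

Compound 4 (`O=Cc1cc(=O)[nH]c(=O)n1[C@@H]1O[C@H](CO)[C@@H](O)[C@H]1O`) puts formyl in place of hydroxyamino on that same aromatic carbon: formyl in place of hydroxyamino on an aromatic carbon. The measured steps that bear on this change are those at the same place, namely a step that the two limits leave unreadable from compound 1 to compound 3, a step that the two limits leave unreadable from compound 2 to compound 3 and a step that the two limits leave unreadable from compound 1 to compound 2. None of them has a readable size, and none of the three groups has brought a compound to a real number in this assay. Within the data shown here, no measured step points to a gain or a loss, and formyl itself is untested at this place, so the range is kept wide. The expected size of a number no higher from compound 3 to compound 4 (the limit leaves the size open) lies within the usual scatter, in neither direction. The estimate for compound 4 is 50000 nM, with an expected range from 10000 nM to 100000 nM.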

Compound 4, half-maximal inhibitory concentration: > 50000 nM
Compound 4: only a limit was reported; the forecaster's own chance of this, stated with the estimate: 75%; the middle value sits exactly at the limit.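

Among these compounds, compound 4 also gives only a limit, so the steps to it from compound 1, compound 2 and compound 3 cannot be read, and no new step emerges. All four compounds stand together: the limit of > 50000 nM in this assay, at which 4 of the 4 values shown sit. The compounds shown leave open whether any group at this place can bring the shared core to a real number in this assay.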